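Lipophilicity from compound 3 to compound 4

The compounds below may be only part of what the source reports. "The series", "measured", "known", "first", "only" and "open" are said of these compounds alone.

Measured in a physicochemical assay for lipophilicity; a higher number here means a more lipophilic compound, a lower number a more polar compound:
Compound 1 `COc1cc(-c2noc([C@H](C)NC(=O)c3cc(C(F)(F)F)nn3C)n2)cc(C)n1` gives 4.4
Compound 2 `C[C@H](NC(=O)c1cc(C(F)(F)F)nn1C)c1nc(-c2ccnc(C3CC3)c2)no1` gives 4.1
Compound 3 `COCc1cc(-c2noc([C@H](C)NC(=O)c3cc(C(F)(F)F)nn3C)n2)ccn1` gives 3

Compound 3 stands lowest of the three in this assay, at 3. Compound 4 `COC(C)(C)c1cc(-c2noc([C@H](C)NC(=O)c3cc(C(F)(F)F)nn3C)n2)ccn1` differs from it as follows: 1-methoxy-1-methylethyl in place of methoxymethyl on an aromatic carbon. In words, 1-methoxy-1-methylethyl sits in place of methoxymethyl, next to the ring nitrogen. Within the data shown here, no measured step makes this exact change. The nearest evidence is a number 1.10 log units lower from compound 2 to compound 3 (beyond the scatter), where methoxymethyl replaces cyclopropyl, and a number 1.40 log units lower from compound 1 to compound 3 (beyond the scatter). Both steps are large, and both end at compound 3. A moderate rise, smaller than either step, is therefore expected. The expected change is a number 0.70 log units higher from compound 3 to compound 4 (beyond the scatter). For compound 4 the estimated value is 3.7, with an expected range of 3.3 to 4.2.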

Compound 4, distribution coefficient: 3.8
Estimate against measurement, compound 4: 0.10 log units below, and the stated range covers the measured number.
By their numbers in this assay, from the lowest: compound 3; then compounds 4, 2 and 1 (each within the scatter of the next, the first and the last beyond it).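

In this assay, putting 1-methoxy-1-methylethyl in place of methoxymethyl next to the ring nitrogen gives a number 0.80 log units higher from compound 3 to compound 4 (beyond the scatter) while the hydrogen-bond acceptor count stays the same, so added carbon alone moves the number at this position. The comparison with cyclopropyl gives a number 0.30 log units lower from compound 2 to compound 4 (within the scatter) and shows that keeping the ether oxygen does not by itself hold the number down here. No measurement shown gives a cause for this rise. The compounds shown leave open how an amine or a carboxylic acid at this position would read, and whether a longer ether chain would go further.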